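The source may report more compounds than this note shows. Statements on the series, on what has been measured and on what is new or still open speak of the compounds shown alone.

Measured compounds:
compound 1 `Cc1ccc(CO/N=C/c2c(C)nn(C)c2Oc2ccc(Cl)cc2)cc1`, 30.4%
compound 2 `Cc1nn(C)c(Oc2ccccc2)c1/C=N/OCc1ccc(C(F)(F)F)cc1`, 11%
compound 3 `Cc1nn(C)c(Oc2ccccc2)c1/C=N/OCc1ccc([N+](=O)[O-])cc1`, 18.3%

In a functional assay on MKN-45 cells (Homo sapiens) for antiproliferative activity, tested at 1 uM (on this read-out lower numbers stand for less inhibition and higher numbers for more inhibition at the one concentration tested (going by the name of the read-out)), compound 3 gives 18.3%, the second highest of the three numbers. Its nearest neighbour is compound 2, which gives 11%, and the two lie within the scatter of each other; compound 1 gives 30.4%, beyond the scatter above compound 3. Compound 4 `Cc1ccc(CO/N=C/c2c(C)nn(C)c2Oc2ccccc2)cc1` differs from compound 3 in one place: methyl in place of nitro on an aromatic carbon. Within the data shown here, no measured step swaps nitro for methyl. Among the measured compounds shown here, the only step at this position, a number 7.3 percentage points higher from compound 2 to compound 3 (within the scatter), was within the scatter, so exchanging groups here has so far moved this assay little. Compound 1 also carries methyl at this place, though with a different second ring, and gives the highest number. Compound 4 is therefore expected to give 22%, between 8% and 38%, a step of a number 3.7 percentage points higher from compound 3 to compound 4 (within the scatter) that need not exceed the scatter.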

Compound 4, a percentage reported as inhibition, at one concentration (the size of the read-out at that concentration, not a potency): 17.9%
Compound 4: the middle estimate sits 4.1 percentage points above what was measured, within the range that was stated.
By their numbers in this assay, from the lowest: compounds 2, 4 and 3 (each within the scatter of the next); then compound 1.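

In this assay methyl at this place cannot be told apart from the two other groups: exchanging nitro for it gives a number 0.4 percentage points lower from compound 3 to compound 4 (within the scatter) and exchanging trifluoromethyl for it gives a number 6.9 percentage points higher from compound 2 to compound 4 (within the scatter) and so all three groups lie within the scatter. The larger change lies at another place, where hydrogen in place of chloro gives a number 12.5 percentage points lower from compound 1 to compound 4 (beyond the scatter) and shows that this assay can separate these compounds. Nothing at hand explains either result.

As far as these compounds go, whether an amine or a carboxylic acid at the 4-position of this phenyl would move the number remains open. So does whether the chloro step holds when nitro or trifluoromethyl sits at this place.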